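Adding fluoro to compound 2

The source may report more compounds than this note shows. Statements on the series, on what has been measured and on what is new or still open speak of the compounds shown alone.

In an ADME assay on microsomes from liver (Homo sapiens) for metabolic stability, using NADPH, with a stated time of 40 min, tested at 2 uM (a higher number here means that the compound lasts longer, a lower number that the compound disappears faster), compound 1 `Fc1cc(F)c2[nH]cc(-c3ccc4ccccc4n3)c2c1` gives 0.45 h and compound 2 `Cc1cccc2c(-c3ccc4ccccc4n3)c[nH]c12` gives 0.35 h as half-life, two values within the scatter of each other. Compound 3 `Cc1cc(F)cc2c(-c3ccc4ccccc4n3)c[nH]c12` is reached from compound 2 by fluoro in place of hydrogen on an aromatic carbon with fluoro in place of hydrogen on an aromatic carbon. Among the compounds with values here, no measured pair shows this change alone. Compound 1 also carries fluoro and gives 0.45 h in this assay within the scatter of compound 2, so no step beyond the scatter is expected. The estimated 1.3-fold higher number from compound 2 to compound 3 (0.11 log units; within the scatter) is small and, if anything, upward. In this assay the half-life expected for compound 3 is 0.45 h with 0.25 h to 0.8 h as its estimated range.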

Compound 3, half-life: 1.1 h
Beside the measured number, compound 3's estimate is 2.4-fold (0.39 log units) below it; the whole stated range lies below it.
By their numbers in this assay, from the lowest: compounds 2 and 1 (each within the scatter of the next); then compound 3.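

In this assay, fluoro in place of hydrogen on the aromatic carbon meta to the methyl group gives a 3.1-fold higher number from compound 2 to compound 3 (0.50 log units; beyond the scatter) and so matters at this position, although compound 1 and compound 2 lie within the scatter of each other. With this fluoro present in both compounds, methyl in place of the other fluoro gives a 2.4-fold higher number from compound 1 to compound 3 (0.39 log units; beyond the scatter) and shows that the methyl group and this fluoro together set compound 3 apart. No measurement here accounts for the longer half-life. Still open, going by these compounds, is whether chloro, methoxy or an amine at this position would give a similar half-life.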